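Fluoromethyl Added to a Smaller Amide Core

The compounds below may be only part of what the source reports. "The series", "measured", "known", "first", "only" and "open" are said of these compounds alone.

Of the compounds shown here, three sharing one core have been measured in a physicochemical assay for lipophilicity, at pH 7.4; a lower number here means a more polar compound, a higher number a more lipophilic compound. Compound 1 `CNC(=O)c1cc(C(=O)N[C@H]2[C@@H]3COC[C@@H]32)cc2c1OC[C@H]2c1ccccc1` gives 3.3. Compound 2 `CNC(=O)c1cc(C(=O)N[C@H]2[C@@H]3COC[C@@H]32)cc2c1O[C@H](CF)[C@H]2c1ccccc1` differs from it by fluoromethyl in place of hydrogen on a saturated ring carbon and gives 3.6, a step recorded as a number 0.30 log units higher from compound 1 to compound 2 (within the scatter). Compound 3 `CNC(=O)c1cc(C(N)=O)cc2c1OC[C@H]2c1ccccc1` gives 2.7, the lowest of the three numbers; its core differs from the core of compound 1 by a hydrogen atom in place of a group of 6 heavy atoms (5 carbon, 1 oxygen; one three-membered non-aromatic ring of carbon only, one five-membered non-aromatic ring with 1 hetero atom), on an amide-type nitrogen, and the step from compound 1 is a number 0.60 log units lower from compound 1 to compound 3 (beyond the scatter).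

Compound 4 `CNC(=O)c1cc(C(N)=O)cc2c1O[C@H](CF)[C@H]2c1ccccc1` has not yet been measured. It differs from compound 3 by fluoromethyl in place of hydrogen on a saturated ring carbon, and the same change, in the same place, was made from compound 1 to compound 2. For the measured compounds named here, the expected step is a number 0.30 log units higher from compound 3 to compound 4 (within the scatter), set beside the earlier step of a number 0.30 log units higher from compound 1 to compound 2 (within the scatter); this expectation rests on compound 3 starting at 2.7 and on the only comparable pair showing a small movement. Compound 4 is therefore estimated at 3, with a likely range from 2.6 to 3.4.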

Compound 4, distribution coefficient: 2.9
Estimate against measurement, compound 4: 0.10 log units above; low and high end bracket the measured number.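

In this assay, fluoromethyl in place of hydrogen gives a number 0.20 log units higher from compound 3 to compound 4 (within the scatter) and, on the larger core, a number 0.30 log units higher from compound 1 to compound 2 (within the scatter) so on both cores the change moves the number no further than repeat measurements would. With fluoromethyl in place, the swap on the amide-type nitrogen gives a number 0.70 log units lower from compound 2 to compound 4 (beyond the scatter) and without it gives a number 0.60 log units lower from compound 1 to compound 3 (beyond the scatter) so this swap is beyond the scatter in both pairs. Carrying the change across held up in these two pairs, but two pairs make no rule for other cores, and nothing measured here offers a reason for any of these steps.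

Still open, on these data alone, is whether a trifluoromethyl, a hydroxymethyl or an amine on the same saturated ring carbon would also stay within the scatter. Also open, as far as these compounds go, is whether the fluoromethyl step would stay this small on a core with a carboxylic acid or a longer chain on the amide-type nitrogen.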